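The source may hold more compounds than are shown below. What is called first, only, known or untested is meant among the compounds shown, and "the series" means these compounds.

Series notes. Antiproliferative potency is followed in a functional assay on MCF7 cells (Homo sapiens) for antiproliferative activity, read by MTT assay, with a stated time of 72 h; a higher number here means a weaker inhibitor, a lower number a stronger inhibitor. Compound 1 `COc1ccc2oc(CSC(=S)N3CCOCC3)cc(=O)c2c1` is the reference point of the set. In this assay compound 1 gives > 25000 nM, which is a limit of the assay and not a number. Among the measured compounds shown here, compound 2 `O=c1c(CSC(=S)N2CCCC2)coc2ccccc12` differs from compound 1 in more than one place, so no single step between those two is followed. In this assay compound 2 gives > 25000 nM, again only a limit. Compound 1 thus stands at the limit of > 25000 nM in this assay, at which 2 of the 2 values shown sit; no value in the set lies away from that limit, and the two values show nothing of order between compound 1 and compound 2.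

The compound still to be measured is compound 3 `COc1ccc2oc(CSC(=S)N(C(C)C)C(C)C)cc(=O)c2c1`. It carries diisopropylamino in place of morpholin-4-yl on a thiocarbonyl carbon, that is, diisopropylamino in place of morpholin-4-yl on a thiocarbonyl carbon. For the measured compounds named here, no step between measured compounds is available to size this change, and since compound 1 sits at a limit, a step from it cannot be read as a number. The step from compound 1 to compound 3 is expected to be a step that the limit leaves unreadable from compound 1 to compound 3, nothing beyond the scatter as far as the limit allows. Compound 3 is estimated at 30000 nM, expected between 8000 nM and 100000 nM, most probably again reported only as a limit.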

Compound 3, half-maximal inhibitory concentration: > 25000 nM
Compound 3 gave a limit, no number (the forecaster's own chance of this, stated with the estimate: 70%); the middle value does not contradict the limit.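

No step can be read from compound 1 to compound 3 in this assay, as each of the two is reported only as a limit of the assay and not as a number. The compounds shown leave open how the groups on the thiocarbonyl carbon rank, and whether any of these compounds has a potency that can be given as a number: the limit of > 25000 nM in this assay, at which 3 of the 3 values shown sit.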